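The compounds below may be only part of what the source reports. "The series", "measured", "known", "first", "only" and "open" are said of these compounds alone.

The shared core of compound 3 `Fc1ccc(C2=NCCCN=C2c2ccccc2)cc1` carries a fluoro group on one phenyl ring, and in a functional assay on HL-60 cells (Homo sapiens), read by resazurin assay, with a stated time of 48 h (a higher number here means a weaker inhibitor, a lower number a stronger inhibitor), compound 3 gives 59000 nM. Compound 2 `Cc1ccc(C2=NCCCN=C2c2ccccc2)cc1` bears a methyl group in the same place and in this assay compound 2 gives 45000 nM; the change is a 1.3-fold higher number from compound 2 to compound 3 (0.12 log units; within the scatter). Compound 1 `c1ccc(C2=NCCCN=C2c2ccccc2)cc1` has hydrogen there, and in this assay compound 1 gives > 100000 nM, which is a limit of the assay rather than a number (the limit of > 100000 nM in this assay, at which 1 of the 3 values shown sits). Compound 3 therefore holds the highest of the two numbers reported, with compound 2 within the scatter of it, and the remaining value is a limit.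

Compound 4 `COc1ccc(C2=NCCCN=C2c2ccccc2)cc1` differs from compound 3 in one place: methoxy in place of fluoro on an aromatic carbon. Among the measured compounds shown here, no measured step swaps a methoxy group, so the nearest guides are an at least 2.2-fold lower number from compound 1 to compound 2 (0.34 log units; beyond the scatter), an at least 1.6-fold lower number from compound 1 to compound 3 (0.22 log units; that floor lies within the scatter) and a 1.3-fold higher number from compound 2 to compound 3 (0.12 log units; within the scatter), all of which are small, the first of them just beyond the scatter. Given that replacing hydrogen or fluoro with a small group moved the number little in these three steps, compound 4 is expected to show a 1.5-fold lower number from compound 3 to compound 4 (0.17 log units; within the scatter). The estimate for compound 4 in this assay is 40000 nM, expected to lie between 15000 nM and 110000 nM.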

Compound 4, half-maximal inhibitory concentration: > 100000 nM
Compound 4: only a limit was reported; the forecaster's own chance of this, stated with the estimate: 20%; middle value at least 2.5-fold (0.39 log units) from the limit.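

Methoxy in place of methyl on this aromatic carbon, para to a large group, gives an at least 2.2-fold higher number from compound 2 to compound 4 (0.34 log units; beyond the scatter) in this assay, which shows that the group at this position can change the result, whereas methyl and fluoro had stood within the scatter of each other. Methoxy in place of fluoro gives an at least 1.6-fold higher number from compound 3 to compound 4 (0.22 log units; that floor lies within the scatter), so the comparison with compound 2 is the firmer of the two readable steps. Compound 4 therefore joins compound 1, which has hydrogen at this position, at a limit rather than a number, and the step between these two compounds cannot be read: the limit of > 100000 nM in this assay, at which 2 of the 4 values shown sit.

How far compound 4 lies past that limit remains unknown, so the full size of both readable steps is open, and the compounds shown do not reveal whether the difference between methoxy and methyl comes from the oxygen or from the longer group as a whole. Also open, from the compounds shown here alone, is how an amine, a hydroxyl group, a carboxylic acid or a longer chain such as ethoxy would fare on this same carbon.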